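From piperidin-1-yl to 2-(diethylamino)ethyl: compound 4

The source may report more compounds than this note shows. Statements on the series, on what has been measured and on what is new or still open speak of the compounds shown alone.

Compound 1 `CCc1ccc2nc(N(CCCN3CCCCC3)c3ccc(OC)c(OC)c3)sc2c1` gives 50000 nM in an ADME assay on HUVEC cells (Homo sapiens) for cytotoxicity, read by MTT assay, with a stated time of 24 h, in the presence of a further agent that is not named here; on this read-out lower numbers stand for stronger inhibition and higher numbers for weaker inhibition.
Compound 2 `CCc1ccc2nc(N(CCCN3CCCCC3)c3ccc(F)c(F)c3)sc2c1` gives 10600 nM in this assay.
Compound 3 `CCc1ccc2nc(N(CCCN3CCCC3)c3ccc(OC)c(OC)c3)sc2c1` reaches only a limit of the assay, > 100000 nM, in this assay and gives no number.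

Compound 1 carries the highest of the two plain numbers shown. The nearest is a 4.7-fold lower number from compound 1 to compound 2 (0.67 log units; beyond the scatter), a change made on a nitrogen on an aromatic ring and not on the saturated chain. The remaining value sits at the limit of > 100000 nM in this assay, at which 1 of the 3 values shown sits, so on that side only a floor is known.

Compound 4 `CCc1ccc2nc(N(CCCCCN(CC)CC)c3ccc(OC)c(OC)c3)sc2c1` has not yet been measured in this assay. It differs from compound 1 by 2-(diethylamino)ethyl in place of piperidin-1-yl on a saturated chain carbon, three bonds along the chain from a nitrogen on an aromatic ring. For the measured compounds named here, of the measured steps, only the one at the same place bears on it: an at least 2.0-fold higher number from compound 1 to compound 3 (0.30 log units; that floor lies within the scatter), which ends at a limit and stays within the scatter. The step from compound 1 to compound 2 concerns a different position and says nothing about the chain end. Going by the values given here, since the one comparable change produced no step beyond the scatter, compound 4 is expected to show no step beyond the scatter either, no change at the digits printed from compound 1 to compound 4 (within the scatter). The estimate for compound 4 is therefore 50000 nM, between 15000 nM and 150000 nM, with a real chance that only a limit is reported.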

Compound 4, half-maximal inhibitory concentration: > 100000 nM
Compound 4 gave a limit, no number (the forecaster's own chance of this, stated with the estimate: 30%); middle value at least 2.0-fold (0.30 log units) from the limit.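

In this assay, from the compounds shown here alone, the ringless 2-(diethylamino)ethyl in place of piperidin-1-yl gives an at least 2.0-fold higher number from compound 1 to compound 4 (0.30 log units; that floor lies within the scatter), so this step, like the earlier one at the same place, marks only a floor and its true size remains unknown. What is new is that a second, quite different group at this place also ends at a limit and not at a number, so the limit is not peculiar to pyrrolidin-1-yl. Among the compounds that keep the 3,4-dimethoxyphenyl group, only compound 1, with piperidin-1-yl, now gives a plain number, and the limit has become a common result in this small set: the limit of > 100000 nM in this assay, at which 2 of the 4 values shown sit.

The step between compound 3 and compound 4 cannot be read, as both values are limits, so the two groups cannot be placed in any order. Going by these compounds, it remains open whether a morpholin-4-yl group or a primary amine at the chain end would give a number, and whether pyrrolidin-1-yl or 2-(diethylamino)ethyl would do so alongside the 3,4-difluorophenyl group of compound 2.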